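Series on a Shared Core: a Step Without Measured Guidance

A few compounds are considered here, and "the series" means these few. Any claim that something is new, unique, unknown or untested is made for them only; others in the source may bear on it.

Compound 1 `Cc1cc(Cc2ccccc2)c(=O)n(CC(=O)Nc2ccc(Br)cc2)n1`; in a functional assay on HL-60 cells (Homo sapiens), read by calcium flux (on this read-out higher numbers stand for an effect only at larger amounts of compound and lower numbers for an effect already at smaller amounts), compound 1 gives > 50000 nM, a limit of the assay.
Compound 2 `Cc1cc(Cc2cccc(Br)c2)c(=O)n(CC(=O)Nc2ccc(Br)cc2)n1`; in this assay compound 2 gives > 50000 nM, a limit of the assay.
Compound 3 `COc1ccc(Nc2cc(C)nn(CC(=O)Nc3ccc(Br)cc3)c2=O)cc1`; in this assay compound 3 gives > 50000 nM, a limit of the assay.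

Compound 3 stands where every measured compound in this set stands: at the limit of > 50000 nM in this assay, at which 3 of the 3 values shown sit, with no number beneath it. The three compounds differ only on one aromatic carbon of the shared core, and the measured steps between them are a step that the two limits leave unreadable from compound 1 to compound 2, a step that the two limits leave unreadable from compound 1 to compound 3 and a step that the two limits leave unreadable from compound 2 to compound 3; none of them can be read, since both ends are limits.

Compound 4 `COc1ccc(-c2cc(C)nn(CC(=O)Nc3ccc(Br)cc3)c2=O)cc1` differs from compound 3 by 4-methoxyphenyl in place of (4-methoxyphenyl)amino on an aromatic carbon. Within the data shown here, no measured step in this set bears on this change in a readable way, so the expectation for compound 4 can rest only on the fact that every measured neighbour sits at the limit. The step from compound 3 to compound 4 is therefore estimated as a number no higher from compound 3 to compound 4 (the limit leaves the size open), meaning no change beyond the scatter is expected, though no direction can be excluded. For compound 4 the estimate in this assay is 50000 nM, expected to lie between 10000 nM and 200000 nM, most likely reported again as a limit.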

Compound 4, half-maximal effective concentration: > 50000 nM
Compound 4 was reported as a limit (the forecaster's own chance of this, stated with the estimate: 80%); the middle value sits exactly at the limit.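

The steps from compound 4 to compounds 1, 2 and 3 cannot be read, as both ends of each are limits, not numbers: the limit of > 50000 nM in this assay, at which 4 of the 4 values shown sit.

The compounds shown leave open how benzyl, 3-bromobenzyl, (4-methoxyphenyl)amino and 4-methoxyphenyl on this aromatic carbon truly compare in this assay, and which structure would give a measurable value.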